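Aryl variation at the chain carbon of the shared core

The source may hold more compounds than are shown below. What is called first, only, known or untested is meant among the compounds shown, and "the series" means these compounds.

Measured so far:
compound 1 `CNC(=O)c1ccc([C@H](C(=O)NC(C)C)N2C(=O)[C@@H](C3Cc4ccccc4C3)NC(=O)[C@H]2CC(C)C)o1` — 39.8 nM
compound 2 `CC(C)C[C@@H]1C(=O)N[C@H](C2Cc3ccccc3C2)C(=O)N1[C@@H](C(=O)NC(C)C)c1ccc(-c2ccccn2)s1` — 2.51 nM
compound 3 `Cc1nc([C@H](C(=O)N(C)C)N2C(=O)[C@@H](C3Cc4ccccc4C3)NC(=O)[C@H]2CC(C)C)c(C)o1` — 3.16 nM

In an assay on isolated protein for binding affinity to Oxytocin receptor (Homo sapiens) (on this read-out higher numbers stand for weaker inhibition and lower numbers for stronger inhibition), compound 2 gives 2.51 nM, the lowest number of the three; compound 3 stands within the scatter of it, while compound 1 stands well apart. Among the measured compounds shown here, the only measured step at this position, a 16-fold lower number from compound 1 to compound 2 (1.20 log units; beyond the scatter), shows that the aryl group here moves the number strongly. Compound 4 `CC(C)C[C@@H]1C(=O)N[C@H](C2Cc3ccccc3C2)C(=O)N1[C@@H](C(=O)NC(C)C)c1coc(C(F)(F)F)n1` carries the change (a group of 9 heavy atoms (4 carbon, 1 nitrogen, 1 oxygen, 3 fluorine; one five-membered aromatic ring with 2 hetero atoms) in place of a group of 11 heavy atoms (9 carbon, 1 nitrogen, 1 sulfur; one five-membered aromatic ring with 1 hetero atom, one six-membered aromatic ring with 1 hetero atom), on a saturated chain carbon bound to an amide-type nitrogen in a ring and a carbonyl carbon). For the measured compounds named here, no measured step covers this exact exchange; compound 3 shows that a five-membered aromatic ring with two hetero atoms can give a low number, but it also differs in the amide. A moderate rise, a 3.2-fold higher number from compound 2 to compound 4 (0.50 log units; beyond the scatter), is therefore expected, with compound 4 estimated at 8 nM (range 2 nM to 30 nM).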

Compound 4, inhibition constant: 0.159 nM
The estimate for compound 4 lay 50-fold (1.70 log units) above the measured number, outside the stated range (below it).
By their numbers in this assay, from the lowest: compound 4; then compounds 2 and 3 (each within the scatter of the next); then compound 1.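

In this assay, replacing the 5-(pyridin-2-yl)thiophen-2-yl group with the trifluoromethyl-bearing five-membered aromatic ring with two hetero atoms gives a 16-fold lower number from compound 2 to compound 4 (1.20 log units; beyond the scatter), so the second aromatic ring is not needed for a low number at this position. Compounds carrying a single five-membered aromatic ring here also span a wide spread, with a 250-fold lower number from compound 1 to compound 4 (2.40 log units; beyond the scatter). Nothing available explains the size of either step.

Open, going by these compounds, is how much of the gain belongs to the trifluoromethyl group and how much to the ring itself. The same ring carrying a methyl group, a nitrile or a carboxylic acid instead would separate the two.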